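A few compounds are considered here, and "the series" means these few. Any claim that something is new, unique, unknown or untested is made for them only; others in the source may bear on it.

The measured compounds:
compound 1, `CC1=C(/C=C/C(=O)/C=C/c2ccc(Cl)cc2)C(C)(C)CCC1`, 33200 nM
compound 2, `CC1=C(/C=C/C(=O)/C=C/c2ccc(Br)cc2)C(C)(C)CCC1`, 88800 nM
compound 3, `CC1=C(/C=C/C(=O)/C=C/c2ccc(C#N)cc2)C(C)(C)CCC1`, 22200 nM

All three numbers come from a functional assay on HeLa cells (Homo sapiens) for cytotoxicity, read by sulforhodamine B assay, with a stated time of 48 h; a higher number here means a weaker inhibitor, a lower number a stronger inhibitor. Compound 3 carries the lowest number shown, yet the step of a 1.5-fold lower number from compound 1 to compound 3 (0.17 log units; within the scatter) lies within the scatter, so compound 3 and compound 1 cannot be told apart on these data; only compound 2 sits clearly apart, as the step of a 4.0-fold lower number from compound 2 to compound 3 (0.60 log units; beyond the scatter) shows. Compound 4, `COc1ccc(/C=C/C(=O)/C=C/C2=C(C)CCCC2(C)C)cc1`, has not yet been measured in this assay. It differs from compound 3 in one place: methoxy in place of cyano on an aromatic carbon. Among the measured compounds shown here, the steps that bear on this change are those at the same aromatic carbon, a 1.5-fold lower number from compound 1 to compound 3 (0.17 log units; within the scatter), a 4.0-fold lower number from compound 2 to compound 3 (0.60 log units; beyond the scatter) and a 2.7-fold higher number from compound 1 to compound 2 (0.43 log units; beyond the scatter). For the measured compounds named here, none of them involves methoxy, so they show only that exchanging the group on this carbon has moved the number by small to modest amounts in either direction. A step of similar size, without a firm direction, is therefore expected for compound 4. Compound 4 is estimated at 30000 nM, between 12000 nM and 75000 nM. That estimate means an expected step of a 1.4-fold higher number from compound 3 to compound 4 (0.13 log units; within the scatter).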

Compound 4, half-maximal inhibitory concentration: 15700 nM
The estimate for compound 4 lay 1.9-fold (0.28 log units) above the measured number; low and high end bracket the measured number.
By their numbers in this assay, from the lowest: compounds 4, 3 and 1 (each within the scatter of the next, the first and the last beyond it); then compound 2.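

In this assay, the step of a 1.4-fold lower number from compound 3 to compound 4 (0.15 log units; within the scatter) leaves methoxy and cyano indistinguishable at this aromatic carbon, para to a large group. Methoxy nevertheless stands clear of both halogens, through a 2.1-fold lower number from compound 1 to compound 4 (0.33 log units; beyond the scatter) and a 5.7-fold lower number from compound 2 to compound 4 (0.75 log units; beyond the scatter), whereas cyano stood clear of bromo only. No evidence is available to explain these differences.

The compounds shown leave open how an amine, a hydroxyl or a carboxylic acid on this carbon would compare with methoxy and cyano. They also leave open whether a longer chain on the oxygen, such as ethoxy, would keep the number of compound 4 at 15700 nM or move it away.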